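Methyl placement on the fused ring: compound 2 to compound 3

This account rests on a few compounds, and the source may have more. Where it says the series, first, only, none or still open, it means among the compounds named here.

Measured so far:
compound 1 `Cc1cccc2c1OCN(c1ccc3oc(-c4ccccc4)cc(=O)c3c1)C2`: 30.4%
compound 2 `O=c1cc(-c2ccccc2)oc2ccc(N3COc4ccccc4C3)cc12`: 8.7%

In a functional assay on MCF7 cells (Homo sapiens) for inhibition, read by MTT assay, with a stated time of 48 h, tested at 7.5 ug/mL (a higher number here means more inhibition of growth at the concentration tested, a lower number less inhibition of growth), compound 2 gives 8.7%, the lowest of the two numbers in hand. Its nearest neighbour is compound 1, which in this assay gives 30.4% and carries a methyl on the fused ring of the shared core where compound 2 carries a hydrogen.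

Compound 3 `Cc1ccc2c(c1)CN(c1ccc3oc(-c4ccccc4)cc(=O)c3c1)CO2` is the next member: methyl in place of hydrogen on an aromatic carbon. Among the measured compounds shown here, only one measured step bears on this change, a number 21.7 percentage points lower from compound 1 to compound 2 (beyond the scatter), which removed a methyl from the same fused ring, though from a different aromatic carbon. That step was beyond the scatter and modest in size. Putting a methyl back on this ring, at the new place, is therefore expected to move the number upward by a step of comparable order, with the uncertainty that the place is not the same as in compound 1.

For compound 3 the expected value in this assay is 22%, with a range of 6% to 38%. The step this implies, a number 13.3 percentage points higher from compound 2 to compound 3 (beyond the scatter), is an estimate only.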

Compound 3, percent growth inhibition at one concentration: 16.5%
Estimate against measurement, compound 3: 5.5 percentage points above, and the stated range covers the measured number.
By their numbers in this assay, from the lowest: compounds 2 and 3 (each within the scatter of the next); then compound 1.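

In this assay, putting a methyl on the carbon that stands meta to a fused ring and para to a fused ring gives a number 7.8 percentage points higher from compound 2 to compound 3 (within the scatter) and so does not set compound 3 apart from compound 2 beyond the scatter. The earlier step, a number 21.7 percentage points lower from compound 1 to compound 2 (beyond the scatter) on removal of a methyl from a different aromatic carbon of the same ring, therefore does not carry over to every carbon of that ring: a methyl on this ring is not enough by itself, since compound 3 gives 16.5% in this assay while compound 1 gives 30.4% with its methyl at the other carbon. No measurement at hand gives a reason for this difference between the two carbons.

Whether this carbon tolerates change without any shift in this assay or merely shows none with methyl remains open, since one small group is the only substituent shown there. A methoxy group, an amine, a carboxylic acid or a longer chain such as ethyl at this carbon, and the same groups at the carbon bearing the methyl of compound 1, would separate these two readings.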